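The source may hold more compounds than are shown below. What is called first, only, known or untested is meant among the compounds shown, and "the series" means these compounds.

Measured compounds:
- compound 1 `CCCCCCCC/C=C\CCCCCCCC(=O)Nc1nnc(S[C@@H]2O[C@H](COC(C)=O)[C@H](OC(C)=O)[C@H](OC(C)=O)[C@H]2OC(C)=O)s1`: 26300 nM
- compound 2 `CCCCCCCCCCCCCCCCCC(=O)Nc1nnc(S[C@@H]2O[C@H](CO)[C@H](O)[C@H](O)[C@H]2O)s1`: "not active" (no number reported)
- compound 3 `CCCCCCCC(=O)Nc1nnc(S[C@@H]2O[C@H](COC(C)=O)[C@H](OC(C)=O)[C@H](OC(C)=O)[C@H]2OC(C)=O)s1`: 19200 nM

Within the data shown here, in an ADME assay on CHO-K1 cells (Cricetulus griseus) for cytotoxicity, read by MTT assay, with a stated time of 24 h (on this read-out higher numbers stand for weaker inhibition and lower numbers for stronger inhibition), compound 1 gives 26300 nM and compound 3 gives 19200 nM; the one step between measured compounds, a 1.4-fold lower number from compound 1 to compound 3 (0.14 log units; within the scatter), shows that shortening the chain on the acetylated core leaves the read-out essentially unchanged. Compound 2 stands apart: in this assay compound 2 gives "not active" (no number reported), so no number is available for it and its place relative to compound 1 and compound 3 cannot be fixed.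

Compound 4 `CCCCCC(=O)Nc1nnc(S[C@@H]2O[C@H](CO)[C@H](O)[C@H](O)[C@H]2O)s1` is to be measured in this assay. It differs from compound 2 as follows: hydrogen in place of dodecyl on a saturated chain carbon, five bonds along the chain from a carbonyl carbon. Among the measured compounds shown here, the only comparable step, a 1.4-fold lower number from compound 1 to compound 3 (0.14 log units; within the scatter), was within the scatter, so no step beyond the scatter is expected from compound 2 to compound 4 in this assay. Since compound 2 returned no number, compound 4 is expected to behave similarly and may well return only a limit. The estimate for compound 4 is 60000 nM, with a range from 20000 nM to 250000 nM.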

Compound 4, half-maximal inhibitory concentration: "not active" (no number reported)
The entry for compound 4 holds no number; the estimate stays without a comparison.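

In this assay compound 2 gives "not active" (no number reported) and compound 4 gives "not active" (no number reported), so no step can be read between them. Where compound 2 and compound 4 stand relative to compound 1 and compound 3 remains open. No supporting data bear on this result.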